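A chlorinated chain replaces the hexanamide tail

The source may hold more compounds than are shown below. What is called first, only, known or untested is meant among the compounds shown, and "the series" means these compounds.

Of the compounds shown here, three sharing one core have been tested in a functional assay on HT-1080 cells (Homo sapiens) for antiproliferative activity, read by sulforhodamine B assay, with a stated time of 48 h; a higher number here means a weaker inhibitor, a lower number a stronger inhibitor. Compound 2 `CCCCCC(=O)Nc1ccc(S(=O)(=O)Oc2ccccc2C(C)C)cc1` gives 6300 nM, the lowest number of the three, though both other values sit within the usual scatter of it. Compound 3 `CCCCCC(=O)Nc1ccc(S(=O)(=O)Oc2ccccc2I)cc1` gives 9600 nM in this assay, and compound 1 `CC(C)c1ccccc1OS(=O)(=O)c1cccc(NC(=O)C(C)(C)C)c1` gives 11000 nM. Within the data shown here, the only step between compounds that differ in a single place, a 1.5-fold higher number from compound 2 to compound 3 (0.18 log units; within the scatter), is within the scatter. Compound 1 differs from compound 2 in more than one place, so its number is read only as a value, not as a step.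

Compound 4 `CC(C)c1ccccc1OS(=O)(=O)c1ccc(NC(=O)CCCCl)cc1` has not yet been measured. It differs from compound 2 by chloro in place of ethyl on a saturated chain carbon, three bonds along the chain from a carbonyl carbon. Among the measured compounds shown here, no measured step touches the amide chain: the step from compound 2 to compound 3 concerns an aromatic carbon, and compound 1 carries a different acyl group altogether. For the measured compounds named here, there is thus no direct precedent for this chain edit; what the three values show is a narrow band for this core. The step of a 1.1-fold higher number from compound 2 to compound 4 (0.05 log units; within the scatter) in this assay is expected to stay within the scatter. Compound 4 is accordingly estimated at 7000 nM in this assay, with a range from 2500 nM to 20000 nM.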

Compound 4, half-maximal inhibitory concentration: 3800 nM
The estimate for compound 4 lay 1.8-fold (0.27 log units) above the measured number, and the stated range covers the measured number.
By their numbers in this assay, from the lowest: compounds 4, 2, 3 and 1 (each within the scatter of the next, the first and the last beyond it).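

In this assay the amide chain now has its first measured step, which reads a 1.7-fold lower number from compound 2 to compound 4 (0.22 log units; within the scatter) and so stays within the scatter. The change from pentyl to 3-chloropropyl, a different element at the chain end as well as a different chain, therefore leaves this pair inside the same narrow band as the aromatic edit, whose step reads a 1.5-fold higher number from compound 2 to compound 3 (0.18 log units; within the scatter) on the same scale, so for this one pair the position tolerates the edit without a clear shift in either direction. No measurement of any property of these groups is available to account for the result.

The single pair cannot separate the part played by the chlorine from the part played by the chain itself, since a plain propyl chain ending in a methyl group, with no chlorine, is absent from the compounds shown. Going by these compounds, how this position responds to a much longer chain, or to an amine or a carboxylic acid at the chain end, also remains open, as does whether any such group would move the number beyond the scatter.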